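A few compounds are considered here, and "the series" means these few. Any claim that something is new, unique, unknown or untested is made for them only; others in the source may bear on it.

Working notes on the series

All three measured compounds share one core and differ only at a single aromatic carbon. In a functional assay on MDA-MB-231 cells (Homo sapiens) for cytotoxicity, read by MTT assay, with a stated time of 48 h (a higher number here means a weaker inhibitor, a lower number a stronger inhibitor), compound 1 `O=C(/C=C/c1ccc2c(c1)B(O)OC2)c1ccc(F)cc1` gives 1600 nM. In this assay compound 2 `CCc1ccc(C(=O)/C=C/c2ccc3c(c2)B(O)OC3)cc1` gives 9800 nM, and compound 3 `O=C(/C=C/c1ccc2c(c1)B(O)OC2)c1ccc(O)cc1` gives 25600 nM. Compound 3 thus stands at the highest number of the three; the step of a 2.6-fold higher number from compound 2 to compound 3 (0.42 log units; beyond the scatter) and the step of a 16-fold higher number from compound 1 to compound 3 (1.20 log units; beyond the scatter) both lie beyond the scatter, so compound 3 is the weakest inhibitor among the measured set.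

Compound 4 `O=C(/C=C/c1ccc2c(c1)B(O)OC2)c1ccc([N+](=O)[O-])cc1` has not been measured. It differs from compound 3 by nitro in place of hydroxy on an aromatic carbon, on an aromatic carbon of a six-membered aromatic ring of carbon only, para to a large group.

For the measured compounds named here, two measured steps bear on this change, both ending at compound 3 with hydroxy entering: a 16-fold higher number from compound 1 to compound 3 (1.20 log units; beyond the scatter) was large, a 2.6-fold higher number from compound 2 to compound 3 (0.42 log units; beyond the scatter) modest. In each case the hydroxy compound gave the higher number. The change to compound 4 removes the hydroxy, so a lower number in this assay is expected; nothing measured shows nitro itself, so the size is uncertain, and a step of about the modest kind, a 6.4-fold lower number from compound 3 to compound 4 (0.81 log units; beyond the scatter), is expected. Compound 4 is therefore estimated at 4000 nM, with a range from 900 nM to 16000 nM.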

Compound 4, half-maximal inhibitory concentration: 11200 nM
The estimate for compound 4 lay 2.8-fold (0.45 log units) below the measured number, within the range that was stated.
By their numbers in this assay, from the lowest: compound 1; then compounds 2 and 4 (each within the scatter of the next); then compound 3.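

Taking out the hydroxy does lower the number in this assay (a 2.3-fold lower number from compound 3 to compound 4 (0.36 log units; beyond the scatter)), but the step is modest and nitro does not come near fluoro (a 7.0-fold higher number from compound 1 to compound 4 (0.85 log units; beyond the scatter)), so the loss of hydroxy alone does not set the number at this position and the entering group matters as well. Nitro and ethyl cannot be told apart in this assay (a 1.1-fold higher number from compound 2 to compound 4 (0.06 log units; within the scatter)), which leaves compound 1 as the strongest inhibitor of the four, with fluoro the only group at this carbon that stands clear of all the others. No measurement accompanies these numbers that could account for the place of any of these groups.

On these data alone, whether an amine, a carboxylic acid, a methoxy or a chloro at this carbon would stay with nitro and ethyl or approach fluoro remains open. All the changes shown also sit at one place, para to a large group, so it remains open whether the same order of groups would hold on another carbon of that ring.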